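Compound 3: a dichlorophenyl swap on a shared core

The source may hold more compounds than are shown below. What is called first, only, known or untested is meant among the compounds shown, and "the series" means these compounds.

Of the compounds shown here, two have so far been measured in a functional assay on PC-12 cells (Rattus norvegicus) for cytotoxicity, read by MTT assay, with stated times of 2 h and 24 h, tested at 10 uM; a lower number here means a weaker effect, a higher number a stronger effect of the compound at the concentration tested. Compound 1 `COc1ccc(-n2nc(-c3ccc(C(F)(F)F)cc3O)nc2-c2ccccc2O)cc1` gives 98.9%, and compound 2 `Oc1cc(C(F)(F)F)ccc1-c1nc(-c2ccccc2O)n(-c2cccc(F)c2)n1` gives 98.3%. Among the measured compounds shown here, the one measured step, a number 0.6 percentage points lower from compound 1 to compound 2 (within the scatter), stays within the scatter, so compound 2 stands lowest of the two numbers only by a margin the method cannot resolve; both values sit close to the top of the scale.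

Compound 3 `Oc1cc(C(F)(F)F)ccc1-c1nc(-c2ccccc2O)n(-c2ccc(Cl)cc2Cl)n1` differs from compound 2 in a single place: 2,4-dichlorophenyl in place of 3-fluorophenyl on an aromatic nitrogen. For the measured compounds named here, the only measured step that bears on this change is the earlier exchange of the group on the same aromatic nitrogen, from 4-methoxyphenyl to 3-fluorophenyl, which moved the read-out by an amount inside the scatter. With both measured numbers already near the ceiling and that exchange leaving no trace, the expected step of a number 1.3 percentage points lower from compound 2 to compound 3 (within the scatter) is none beyond the scatter. Compound 3 is therefore estimated at 97% in this assay, with a range from 86% to 100%.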

Compound 3, a percentage reported as activity, at one concentration (the size of the read-out at that concentration, not a potency): 95.2%
Compound 3: the middle estimate sits 1.8 percentage points above what was measured; the measured number falls inside the stated range.
By their numbers in this assay, from the lowest: compounds 3, 2 and 1 (each within the scatter of the next).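

In this assay, the exchange on the aromatic nitrogen of 3-fluorophenyl for 2,4-dichlorophenyl comes to a number 3.1 percentage points lower from compound 2 to compound 3 (within the scatter), and that of 4-methoxyphenyl for the same group comes to a number 3.7 percentage points lower from compound 1 to compound 3 (within the scatter). The earlier compounds had shown only that a methoxy-bearing and a fluorine-bearing phenyl ring could not be told apart at this position; the series now includes a ring with two chlorine atoms, and this read-out at the single concentration tested still does not separate any of the three compounds. Nothing available explains why the read-out stays unresolved across these groups.

As far as these compounds go, all three compounds keep a six-membered aromatic ring of carbon on this nitrogen, so it remains open whether a methyl group, a longer alkyl chain, or a chain ending in an amine or a carboxylic acid in place of that ring would give a read-out beyond the scatter. With all three numbers close to the top of the scale, a reading at one concentration also leaves open whether the compounds would differ in potency.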